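Adding chloro to compound 2 at the assay limit

This account rests on a few compounds, and the source may have more. Where it says the series, first, only, none or still open, it means among the compounds named here.

In a functional assay on MCF7 cells (Homo sapiens) for cytotoxicity, with a stated time of 72 h (on this read-out lower numbers stand for stronger inhibition and higher numbers for weaker inhibition), compound 1 (`CC1(C)Cc2c(-c3ccncc3)c(-c3ccccc3C#N)nn2C1`) gives > 100000 nM as a limit of the assay and not a number. Compound 2 (`Cc1cccc(-c2nn3c(c2-c2ccncc2)CC(C)(C)C3)n1`) gives > 100000 nM as a limit too. Among the compounds with values here, compound 2 therefore has no readable number, and the only other value beside it is also a limit.

Compound 3 (`Cc1cccc(-c2nn3c(c2-c2ccnc(Cl)c2)CC(C)(C)C3)n1`) changes pyridin-4-yl to 2-chloropyridin-4-yl, and the difference counts as chloro in place of hydrogen on an aromatic carbon with chloro in place of hydrogen on an aromatic carbon.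

Within the data shown here, only one measured step bears on this change, and it is a step that the two limits leave unreadable from compound 1 to compound 2 with no size to carry forward. The evidence amounts to the limit of > 100000 nM in this assay, at which 2 of the 2 values shown sit, and nothing more. Among the measured compounds shown here, no measured step shows what chloro does on this core, so no change beyond the scatter is expected in either direction in this assay and compound 3 will probably also stay at the limit. The expected a number no higher from compound 2 to compound 3 (the limit leaves the size open) is an estimate of no real movement. In this assay compound 3 is estimated at 100000 nM with a range from 40000 nM to 150000 nM expected.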

Compound 3, half-maximal inhibitory concentration: > 100000 nM
Compound 3: a limit, no number; the forecaster's own chance of this, stated with the estimate: 80%; the middle value lies on the limit itself.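

In this assay compound 3 gives > 100000 nM, which is a limit of the assay and not a number. Compound 2 also stands at a limit, so the step between compound 2 and compound 3 cannot be read. The compounds shown leave open what size of effect chloro in place of hydrogen has on the shared core, and whether any change there gives a readable number in this assay.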